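A few compounds are considered here, and "the series" means these few. Any claim that something is new, unique, unknown or untested is made for them only; others in the source may bear on it.

Measured compounds:
Compound 1 `Cc1ccc(C)c(-n2nncc2CN2C(=O)C3(C(C#N)=C(N)Oc4c3c3nc5ccccc5nc3c3ccccc43)c3ccccc32)c1` — in an ADME assay on HUVEC cells (Homo sapiens) for antiproliferative activity, read by MTT assay, with a stated time of 48 h (on this read-out higher numbers stand for weaker inhibition and lower numbers for stronger inhibition), compound 1 gives > 50000 nM, which is a limit and not a number.
Compound 2 `N#CC1=C(N)Oc2c(c3nc4ccccc4nc3c3ccccc23)C12C(=O)N(Cc1cnnn1-c1ccc(F)c(Cl)c1)c1ccccc12` — in this assay compound 2 gives > 50000 nM, again a limit and not a number.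

Within the data shown here, compound 2 therefore stands at the limit in this assay: its value is a limit, and the one further value shown is a limit as well, so that (the limit of > 50000 nM in this assay, at which 2 of the 2 values shown sit). Compound 3 `N#CC1=C(N)Oc2c(c3nc4ccccc4nc3c3ccccc23)C12C(=O)N(Cc1cnnn1-c1cc(Cl)ccc1Cl)c1ccccc12` differs from compound 2 by 2,5-dichlorophenyl in place of 3-chloro-4-fluorophenyl on an aromatic nitrogen. Among the measured compounds shown here, the only measured step that bears on this change is the earlier swap of the aryl group on the same aromatic nitrogen, a step that the two limits leave unreadable from compound 1 to compound 2, and the two limits leave its size unreadable. A further aryl swap at this position thus gives no basis for expecting a readable step in this assay, in either direction, and the expectation is that compound 3 again sits at the limit. The estimate for compound 3 in this assay is 50000 nM, with a range from 20000 nM to 100000 nM. The step this estimate means is a number no higher from compound 2 to compound 3 (the limit leaves the size open), expected to be none beyond the scatter.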

Compound 3, half-maximal inhibitory concentration: > 50000 nM
Compound 3 was reported as a limit; the forecaster's own chance of this, stated with the estimate: 85%; the middle value lies on the limit itself.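

Among these compounds, compound 3, like compound 1 and compound 2, is reported only as a limit, so no step among the three can be read in this assay: the limit of > 50000 nM in this assay, at which 3 of the 3 values shown sit. The compounds shown leave open how far the 2,5-dimethylphenyl, 3-chloro-4-fluorophenyl and 2,5-dichlorophenyl groups differ, and whether any aryl group on this aromatic nitrogen would give a readable number.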